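The compounds below may be only part of what the source reports. "The series", "measured", "known", "first", "only" and "open" are said of these compounds alone.

Compound 3 `COc1cc(OC)c(/C=C/S(=O)(=O)Cc2ccc(OC)c(NC(C)=O)c2)c(OC)c1` gives 810 nM in an ADME assay on MRC5 cells (Homo sapiens) for cytotoxicity, read by MTT assay, with a stated time of 72 h (on this read-out higher numbers stand for weaker inhibition of growth and lower numbers for stronger inhibition of growth), the highest of the two numbers in the set. Compound 1 `COc1cc(OC)c(/C=C/S(=O)(=O)Cc2ccc(OC)c(N)c2)c(OC)c1` gives 80 nM in this assay. Compound 2 `COc1ccc(CS(=O)(=O)/C=C/c2c(OC)cccc2OC)cc1[N+](=O)[O-]` reaches only a limit of the assay, > 30000 nM, in this assay; this is a limit, not a number (the limit of > 30000 nM in this assay, at which 1 of the 3 values shown sits).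

Compound 4 `COc1cc(OC)c(/C=C/S(=O)(=O)Cc2ccc(OC)c([N+](=O)[O-])c2)c(OC)c1` differs from compound 3 by nitro in place of acetamido on an aromatic carbon, ortho to a methoxy group and meta to a large group.

Among the measured compounds shown here, the only measured step that touches this position is a 10-fold higher number from compound 1 to compound 3 (1.01 log units; beyond the scatter), acetyl in place of hydrogen on the ring nitrogen, a large step. For the measured compounds named here, no step between acetamido and nitro is available on this core; compound 2, which carries a nitro group on a different core, shows only a limit. The change from compound 3 to compound 4 removes the donor, and a further rise in the number is expected. For compound 4 the estimate in this assay is 6000 nM, between 1000 nM and 30000 nM, which means an expected step of a 7.4-fold higher number from compound 3 to compound 4 (0.87 log units; beyond the scatter) from compound 3.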

Compound 4, concentration for 50% growth inhibition: 2910 nM
For compound 4 the middle estimate is 2.1-fold (0.31 log units) above the measured one; measured number inside the range.
By their numbers in this assay, from the lowest: compound 1; then compound 3; then compound 4. At a limit, above all of these: compound 2.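

With nitro, amino and acetamido now all read on the shared core in this assay, this position gives a clear order: a 10-fold higher number from compound 1 to compound 3 (1.01 log units; beyond the scatter) for acetyl on the nitrogen, then a 3.6-fold higher number from compound 3 to compound 4 (0.56 log units; beyond the scatter) for nitro in place of acetamido, and overall a 36-fold higher number from compound 1 to compound 4 (1.56 log units; beyond the scatter) for nitro in place of amino. The nitro group alone therefore does not put a compound at the assay limit, since the step of an at least 10-fold lower number from compound 2 to compound 4 (1.01 log units; beyond the scatter) goes with methoxy in place of hydrogen on an aromatic carbon, elsewhere in the molecule. That step has only a bound on its size, as compound 2 gives a limit and not a number: the limit of > 30000 nM in this assay, at which 1 of the 4 values shown sits.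

From the compounds shown here alone, how a hydroxyl group, a dimethylamino group or a longer acyl chain on the nitrogen would stand at this position remains open. Also open, going by these compounds, is whether methoxy in place of hydrogen has a similar effect when amino, not nitro, occupies this position.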